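The source may report more compounds than this note shows. Statements on the series, on what has been measured and on what is new or still open speak of the compounds shown alone.

Measured compounds:
- compound 1 `COc1ccc(C(=O)Nc2ccc(-c3ccncc3)cc2)cc1CCCN(C)C` gives 7.8
- compound 2 `CCOc1ccc(NC(=O)c2ccc(OC)c(CCCN(C)C)c2)cc1` gives 6.9
- compound 3 `COc1ccc(NC(=O)c2ccc(-c3ccncc3)cc2)cc1N1CCN(C)CC1` gives 8

These three compounds were tested in a functional assay (Saphenous vein) with Canis familiaris (Canis lupus familiaris) as the target; a lower number here means a less potent compound, a higher number a more potent compound, by a factor of ten per unit of this negative logarithm. Compound 1 stands second highest of the three. Compound 3 lies only a little higher, and the two are within the scatter of each other, so no order between them can be claimed. Going by the values given here, compound 2 lies clearly lower, and the one measured step that reaches it is a number 0.90 log units lower from compound 1 to compound 2 (beyond the scatter), a modest loss when ethoxy takes the place of pyridin-4-yl.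

The new compound 4 `COc1ccc(C(=O)Nc2ccc(-c3ccc(CO)cc3C)cc2)cc1CCCN(C)C` changes compound 1 at the same position: 4-(hydroxymethyl)-2-methylphenyl in place of pyridin-4-yl on an aromatic carbon. Among the compounds with values here, the only measured step that bears on this position is the one from compound 1 to compound 2, which lost potency when the pyridin-4-yl was removed. Here the pyridin-4-yl is again removed, but a larger carbon ring carrying a hydroxymethyl enters instead, so a smaller loss than that step is expected, and the step is expected to be a number 0.50 log units lower from compound 1 to compound 4 (beyond the scatter). Compound 4 is therefore estimated at 7.3, with a range from 6.6 to 8.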

Compound 4, negative logarithm of the antagonist equilibrium constant: 8.5
The estimate for compound 4 lay 1.20 log units below the measured number, and the stated range ends below it.
By their numbers in this assay, from the lowest: compound 2; then compounds 1 and 3 (each within the scatter of the next); then compound 4.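

The pyridin-4-yl of compound 1 is not required at this position: in this assay, putting 4-(hydroxymethyl)-2-methylphenyl in its place gives a number 0.70 log units higher from compound 1 to compound 4 (beyond the scatter) with no ring nitrogen left in that group. Set against ethoxy, the same group gives a number 1.60 log units higher from compound 2 to compound 4 (beyond the scatter), so the earlier loss did not mean that every replacement of pyridin-4-yl costs potency, and this position can move the number in either direction. Nothing measured here explains why the new group does better.

On these data alone, the new group brings a carbon ring, a methyl and a hydroxymethyl together, and which of these carries the gain stays open. A plain phenyl, or a carboxylic acid or an aminomethyl in place of the hydroxymethyl, would bear on that question.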